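A few compounds are considered here, and "the series" means these few. Any claim that something is new, unique, unknown or untested is made for them only; others in the source may bear on it.

Values in a functional assay on SK-OV-3 cells (Homo sapiens) for antiproliferative activity, read by MTT assay, with a stated time of 72 h; on this read-out lower numbers stand for stronger inhibition and higher numbers for weaker inhibition
compound 1 `O=C(CCc1cccc2c1B(O)OC2)Nc1cccc(-c2ccc(Cl)cc2)c1` gives 220 nM
compound 2 `O=C(CCc1cccc2c1B(O)OC2)Nc1cccc(-c2cccc(OC(F)(F)F)c2)c1` gives 460 nM
compound 3 `CSc1cccc(-c2cccc(NC(=O)CCc3cccc4c3B(O)OC4)c2)c1` gives 150 nM

Two steps fix the standing of compound 3 among these numbers (a 1.5-fold lower number from compound 1 to compound 3 (0.17 log units; within the scatter)) and (a 3.1-fold lower number from compound 2 to compound 3 (0.49 log units; beyond the scatter)), which puts it with compound 1 and apart from compound 2.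

Compound 4 `N#Cc1cccc(-c2cccc(NC(=O)CCc3cccc4c3B(O)OC4)c2)c1` carries cyano in place of methylsulfanyl on an aromatic carbon. Among the measured compounds shown here, no measured step brings in cyano. The closest guide is the other swap of one group for another, a modest one (a 3.1-fold lower number from compound 2 to compound 3 (0.49 log units; beyond the scatter)). A step of similar size is expected, most likely toward a higher number, though the data do not settle the direction. The expected move is an estimated (a 1.9-fold higher number from compound 3 to compound 4 (0.27 log units; within the scatter)). For compound 4 the estimated value is 280 nM (expected range 110 nM to 700 nM).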

Compound 4, half-maximal inhibitory concentration: 120 nM
Compound 4: middle estimate off by 2.3-fold (0.37 log units), on the high side; measured number inside the range.
By their numbers in this assay, from the lowest: compounds 4, 3 and 1 (each within the scatter of the next); then compound 2.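

Read in this assay cyano on this aromatic carbon stays within the scatter of methylsulfanyl (a 1.3-fold lower number from compound 3 to compound 4 (0.10 log units; within the scatter)), so the position accepts a group with a triple bond as well as a sulfur-linked one. The 3-cyanophenyl compound also stays within the scatter of the 4-chlorophenyl compound (a 1.8-fold lower number from compound 1 to compound 4 (0.26 log units; within the scatter)), while the trifluoromethoxy compound remains apart (a 3.8-fold lower number from compound 2 to compound 4 (0.58 log units; beyond the scatter)). Nothing available on these compounds accounts for this pattern.

On these data alone, whether an amine, a carboxylic acid or a longer chain on this carbon would keep the number in the same range remains open.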